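The source may hold more compounds than are shown below. What is called first, only, known or untested is meant among the compounds shown, and "the series" means these compounds.

The compounds share a common core, and for only one of them is a number available. Compound 1 `O=c1ccc2cc(OCc3cc(-c4ccccc4Cl)no3)ccc2o1` was taken into a functional assay on A549 cells (Homo sapiens) for cytotoxicity, read by MTT assay, with a stated time of 48 h (on this read-out lower numbers stand for stronger inhibition and higher numbers for weaker inhibition), where its entry reads "not determined" (no result reported). Compound 2 `O=c1ccc2cc(OCc3cc(-c4cccc5ccccc45)no3)ccc2o1` was also taken into this assay, where its entry likewise reads "not determined" (no result reported). Among the compounds with values here, compound 3 `COc1ccc(-n2cc(COc3ccc4oc(=O)ccc4c3)nn2)cc1` is the single compound with a number: in this assay compound 3 gives 46800 nM, which is a weak effect, since on this read-out a high concentration corresponds to weak inhibition of the cells. Within the data shown here, with only one number in hand, compound 3 cannot be placed above or below anything else; it simply marks the only point on the map.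

Compound 4 `O=c1ccc2cc(OCc3cn(-c4ccc([N+](=O)[O-])cc4)nn3)ccc2o1` has not yet been measured. It differs from compound 3 in one place: nitro in place of methoxy on an aromatic carbon. Among the measured compounds shown here, no pair of measured compounds shows what such a swap does here, so there is no step to lean on. The expectation is therefore a cautious one. Compound 4 is expected to differ from its parent only within the usual scatter, a 1.2-fold lower number from compound 3 to compound 4 (0.09 log units; within the scatter), with no clear direction. In this assay compound 4 is estimated to give about 38000 nM, within a range from 12000 nM to 110000 nM.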

Compound 4, half-maximal inhibitory concentration: 33600 nM
For compound 4 the middle estimate is 1.1-fold (0.05 log units) above the measured one; measured number inside the range.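

In this assay, within the data shown here, this is the first measured step at this position on the aromatic ring, para to a large group: nitro in place of methoxy gives a 1.4-fold lower number from compound 3 to compound 4 (0.14 log units; within the scatter) and so lies within the usual scatter of repeated measurements. The swap from 4-methoxyphenyl to 4-nitrophenyl replaces one group with another of a quite different make-up, with more heavy atoms and one more hydrogen-bond acceptor, yet the two compounds read alike on this cell assay, so this one exchange gives no clear gain or loss. No measurement shown here explains why the two compounds read alike.

From the compounds shown here alone, what remains open is whether any other group at this same position, such as an amine, a carboxylic acid or a longer alkoxy chain, would separate clearly from these two values. One pair also cannot show whether the same exchange would read alike on another part of the molecule or in another cell line, so the finding holds only for compound 3 and compound 4.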